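Cyclopentyl for Butyl on a Shared Purine-Type Core

This account rests on a few compounds, and the source may have more. Where it says the series, first, only, none or still open, it means among the compounds named here.

Measured compounds:
- compound 1 `CCCCn1cnc2c(Nc3cccc(Cl)c3)nc(NCOCc3ccc(/C=C/C(=O)Nc4ccccc4N)cc3)nc21` gives 4.76% in a functional assay on HCT-116 cells (Homo sapiens) for antiproliferative activity, read by CCK-8 assay, with a stated time of 72 h, tested at 2 uM; on this read-out higher numbers stand for a stronger effect at the one concentration tested and lower numbers for a weaker effect
- compound 2 `Nc1ccccc1NC(=O)/C=C/c1ccc(COCNc2nc(Nc3cccc(Cl)c3)c3ncn(C4CCCC4)c3n2)cc1` gives 9.04% in this assay
- compound 3 `CCCCn1cnc2c(Nc3cccc(Cl)c3)nc(NCOCc3ccc(C(=O)Nc4ccccc4N)cc3)nc21` gives 58.9% in this assay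

Compound 4 `Nc1ccccc1NC(=O)c1ccc(COCNc2nc(Nc3cccc(Cl)c3)c3ncn(C4CCCC4)c3n2)cc1` has not been measured yet. It carries the same end group as compound 3, and it differs from compound 3 by cyclopentyl in place of butyl on an aromatic nitrogen. That very change has already been made once, from compound 1 to compound 2, as cyclopentyl in place of butyl on an aromatic nitrogen, and there the step was a number 4.3 percentage points higher from compound 1 to compound 2 (within the scatter). The two place lines read the same word for word, so the change is the same kind of change in the same surroundings.

The two pairs do not share one core. Compound 3 differs from compound 1 by (2-aminophenyl)carbamoyl in place of 2-((2-aminophenyl)carbamoyl)ethenyl on an aromatic carbon, and that change gave a number 54.1 percentage points higher from compound 1 to compound 3 (beyond the scatter), leaving compound 3 with the highest number of the three measured compounds, beyond the scatter from both compound 1 and compound 2.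

Because the earlier step of a number 4.3 percentage points higher from compound 1 to compound 2 (within the scatter) stayed within the scatter, the step from compound 3 to compound 4 in this assay is expected to be small as well, about a number 2.1 percentage points higher from compound 3 to compound 4 (within the scatter). The expectation rests on a single prior example, on a different core, so it is held loosely. Compound 4 is estimated to give about 61% in this assay, with a plausible range from 38% to 80%.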

Compound 4, a percentage reported as inhibition, at one concentration (the size of the read-out at that concentration, not a potency): 29.2%
Estimate against measurement, compound 4: 31.8 percentage points above; measured number below the stated range.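

In this assay, the swap of butyl for cyclopentyl on the aromatic nitrogen gave a number 29.7 percentage points lower from compound 3 to compound 4 (beyond the scatter), so the small step seen on the core of compound 1 did not carry over to the core of compound 3: the same change on two cores in this assay, a number 4.3 percentage points higher (within the scatter) from compound 1 to compound 2 and a number 29.7 percentage points lower (beyond the scatter) from compound 3 to compound 4, 34 percentage points apart, beyond the scatter of two such steps The other change, (2-aminophenyl)carbamoyl in place of 2-((2-aminophenyl)carbamoyl)ethenyl, raised the number on both cores, but it gave a number 20.2 percentage points higher from compound 2 to compound 4 (beyond the scatter), and the size of the step again depended on the group at the other end of the molecule: the same change on two cores in this assay, a number 54.1 percentage points higher (beyond the scatter) from compound 1 to compound 3 and a number 20.2 percentage points higher (beyond the scatter) from compound 2 to compound 4, 34 percentage points apart, beyond the scatter of two such steps These four compounds show that, in this small set, the effect of one change cannot simply be copied from one core to another, but they do not show why the two changes interact, and with a single concentration they say nothing about potency.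

The compounds shown leave open whether the drop on the core of compound 3 is tied to the ring of cyclopentyl or to the larger group as such, which a longer chain such as pentyl or a cyclobutyl group on that nitrogen could help separate. Going by these compounds, it also remains open how a cyclohexyl group on that nitrogen would behave on either core.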